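This account rests on a few compounds, and the source may have more. Where it says the series, first, only, none or still open, it means among the compounds named here.

Among the compounds with values here, compound 3 `CC(C)(C)C1=C(C(=O)O)N2C(=O)[C@H]([C@@H](O)CCc3ccccc3)[C@H]2O1` gives the highest number so far in an ADME assay, in phosphate buffer, at 28 degrees C, at pH 7.0 (a higher number here means that the compound lasts longer, a lower number that the compound disappears faster), at 39 h. Compound 1 `CC(C)(C)C1=C(C(=O)O)N2C(=O)[C@H]([C@H](O)CCc3ccc(O)cc3)[C@H]2O1` stands nearest: in this assay compound 1 gives 24.6 h, within the scatter of compound 3. Within the data shown here, compound 2 `C[C@H](O)[C@H]1C(=O)N2C(C(=O)O)=C(C(C)(C)C)O[C@H]12` is furthest: in this assay compound 2 gives 7.1 h, and the only measured step, a 5.5-fold higher number from compound 2 to compound 3 (0.74 log units; beyond the scatter), lies beyond the scatter. Compound 4 `CC(C)(C)C1=C(C(=O)O)N2C(=O)[C@H]([C@@H](O)CCc3ccc(O)cc3)[C@H]2O1` differs from compound 3 by hydroxy in place of hydrogen on an aromatic carbon. Among the measured compounds shown here, no measured step shares this change. For the measured compounds named here, the single guide is that compound 1, which also carries a 4-hydroxyphenyl, and compound 3 sit within the scatter of each other, while the measured step concerns another part of the molecule. The expected step is therefore a 1.3-fold lower number from compound 3 to compound 4 (0.11 log units; within the scatter), within the scatter. For compound 4 in this assay the estimate is 30 h, ranging from 14 h to 65 h.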

Compound 4, half-life: 21.2 h
Estimate against measurement, compound 4: 1.4-fold (0.15 log units) above; the measured number falls inside the stated range.
By their numbers in this assay, from the lowest: compound 2; then compounds 4, 1 and 3 (each within the scatter of the next).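

In this assay, hydroxy on the aromatic carbon para to a large group gives a step within the scatter (a 1.8-fold lower number from compound 3 to compound 4 (0.26 log units; within the scatter)), so this position tolerates the change as far as the half-life shows. The 4-hydroxybenzyl side chain still holds the gain over the smaller compound 2 (a 3.0-fold higher number from compound 2 to compound 4 (0.48 log units; beyond the scatter)). The stereocentre at the saturated chain carbon makes no difference beyond the scatter (a 1.2-fold lower number from compound 1 to compound 4 (0.06 log units; within the scatter)), and this pair isolates that centre: the fact that compounds 1 and 4 differ only in the configuration as drawn

As far as these compounds go, whether an amine or a fluorine in place of the hydroxy would move the half-life beyond the scatter stays open. So does the outcome of a longer chain leading to the aromatic ring.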